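This account rests on a few compounds, and the source may have more. Where it says the series, first, only, none or still open, it means among the compounds named here.

Measured so far in the series:
compound 1 `COc1cc(-c2nc(Cc3c[nH]c4ccccc34)no2)cc(OC)c1OC` — > 50000 nM, a limit of the assay.
compound 2 `COc1cc(-c2noc(-c3ccccc3)n2)cc(OC)c1OC` — > 50000 nM, a limit of the assay.

In an ADME assay on cells (Splenocyte, Mus musculus, strain BALB/c) for cytotoxicity, read by CCK-8 assay, with a stated time of 48 h (on this read-out higher numbers stand for lower toxicity in this test and lower numbers for higher toxicity in this test), compound 1 gives > 50000 nM, which is a limit and not a number. In this assay compound 2 gives > 50000 nM, likewise only a limit. For the measured compounds named here, compound 2 therefore stands at the limit of > 50000 nM in this assay, at which 2 of the 2 values shown sit, and no measured step between compounds separates it from compound 1.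

Compound 3 `COc1cc(-c2noc(-c3ccc(NC(=O)OC(C)(C)C)cc3)n2)cc(OC)c1OC` has not been measured in this assay. It differs from compound 2 by (tert-butoxycarbonyl)amino in place of hydrogen on an aromatic carbon, a (tert-butoxycarbonyl)amino in place of hydrogen on an aromatic carbon of a six-membered aromatic ring of carbon only.

Going by the values given here, no step in this assay is measured for this kind of change. The expectation is no step beyond the usual scatter, with the read-out again likely to be reported only as a limit. Compound 3 is expected at 50000 nM, between 20000 nM and 100000 nM. The expected step is a number no higher from compound 2 to compound 3 (the limit leaves the size open).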

Compound 3, half-maximal cytotoxic concentration: 9200 nM
Estimate against measurement, compound 3: 5.4-fold (0.74 log units) above; measured number below the stated range.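

Substitution on the phenyl ring of compound 2 is not silent: in this assay, (tert-butoxycarbonyl)amino in place of hydrogen on an aromatic carbon, para to a large group, gives an at least 5.4-fold lower number from compound 2 to compound 3 (0.73 log units; beyond the scatter). For the compounds shown here, compound 3 gives 9200 nM, the first actual number and a sign of higher toxicity in this test. The full size of the step remains open, since its starting point is only a limit: the limit of > 50000 nM in this assay, at which 2 of the 3 values shown sit.

A single change at a single position cannot show whether the step comes from the whole (tert-butoxycarbonyl)amino group or from one part of it, such as the tert-butyl. A free amine or a simple acetamide at the same place would separate these readings, and the compounds shown include neither.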